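The compounds below may be only part of what the source reports. "The series", "measured", "known", "first", "only" and "open" are said of these compounds alone.

Compound 1 `COc1coc(C(=O)CCCCCCc2ccccc2)n1` is reported in an assay on HEK-293T cells for inhibition of diacylglycerol lipase-alpha (Homo sapiens), read by colorimetric assay (on this read-out higher numbers stand for weaker inhibition and lower numbers for stronger inhibition), only as a limit, > 10000 nM.
Compound 2 `CSc1coc(C(=O)CCCCCCc2ccccc2)n1` is reported in this assay only as a limit, > 10000 nM.
Compound 3 `COc1cnc(C(=O)CCCCCCc2ccccc2)o1` is reported in this assay only as a limit, > 10000 nM.

Among the compounds with values here, all three values sit at the limit of > 10000 nM in this assay, at which 3 of the 3 values shown sit, so no step among them can be read. From compound 1 to compound 2 the change is methylsulfanyl in place of methoxy on an aromatic carbon, and the step is a step that the two limits leave unreadable from compound 1 to compound 2. The two cores differ as a group of 7 heavy atoms (4 carbon, 1 nitrogen, 2 oxygen; one five-membered aromatic ring with 2 hetero atoms) in place of a group of 7 heavy atoms (4 carbon, 1 nitrogen, 2 oxygen; one five-membered aromatic ring with 2 hetero atoms), on a carbonyl carbon, with the step that the two limits leave unreadable from compound 1 to compound 3; likewise a step that the two limits leave unreadable from compound 2 to compound 3 stays unreadable.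

Compound 4 `CSc1cnc(C(=O)CCCCCCc2ccccc2)o1` differs from compound 3 by methylsulfanyl in place of methoxy on an aromatic carbon. This is the same kind of change as from compound 1 to compound 2, but the place differs: there it sits next to the ring nitrogen, two ring bonds from the ring oxygen; here next to the ring oxygen, two ring bonds from the ring nitrogen.

Compound 3 itself sits only at a limit, > 10000 nM. Since the earlier step of this kind is a step that the two limits leave unreadable from compound 1 to compound 2, the step from compound 3 to compound 4 is expected to be a step that the limit leaves unreadable from compound 3 to compound 4. Compound 4 is therefore estimated at 30000 nM, likely between 8000 nM and 200000 nM, and most probably reported again only as a limit.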

Compound 4, half-maximal inhibitory concentration: > 10000 nM
Compound 4: a limit, no number; the forecaster's own chance of this, stated with the estimate: 85%; the middle value is on the limit's open side.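

In this assay compound 4 gives > 10000 nM, which is only a limit, so its steps from compound 1, compound 2 and compound 3 cannot be read. All four compounds stand at the same limit: the limit of > 10000 nM in this assay, at which 4 of the 4 values shown sit.

The compounds shown leave open how strongly each one inhibits, and whether methylsulfanyl in place of methoxy changes inhibition at all.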